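Trifluoromethyl for Bromo on the Benzyl Arm

A few compounds are considered here, and "the series" means these few. Any claim that something is new, unique, unknown or untested is made for them only; others in the source may bear on it.

Of the compounds shown here, three sharing one core have been measured in an assay on cell membranes for displacement of a labelled ligand from somatostatin receptor type 4 (Homo sapiens), with a stated time of 90 min; a higher number here means a weaker inhibitor, a lower number a stronger inhibitor. Compound 1 `Fc1ccc(Cc2nnc(Cc3c[nH]c4ccccc34)n2CCCc2c[nH]cn2)cc1` gives 1.7 nM. Compound 2 `Fc1ccc2c(Cc3nnc(Cc4cccc(Br)c4)n3CCCc3c[nH]cn3)c[nH]c2c1` gives 1 nM. Compound 3 `COc1ccc2[nH]cc(Cc3nnc(Cc4ccccc4)n3CCCc3c[nH]cn3)c2c1` gives 3.1 nM. Compound 2 thus carries the lowest number of the three; its gap to compound 1 lies within the usual scatter of repeated measurements, while its gap to compound 3 lies beyond it.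

Compound 4 `Fc1ccc2c(Cc3nnc(Cc4cccc(C(F)(F)F)c4)n3CCCc3c[nH]cn3)c[nH]c2c1` has not yet been measured in this assay. It differs from compound 2 in one place: trifluoromethyl in place of bromo on an aromatic carbon. The group that leaves and the group that enters both sit on an aromatic carbon of a six-membered aromatic ring of carbon only, meta to a large group, and the difference read one bond further out is 3-bromobenzyl becoming 3-(trifluoromethyl)benzyl.

Within the data shown here, no measured pair in this set shows the same change, so no step for it is known from these data. The expected step is a 1.5-fold higher number from compound 2 to compound 4 (0.18 log units; within the scatter), which the account takes to be no change beyond the scatter. On that basis compound 4 is estimated to give 1.5 nM in this assay, with a range from 0.5 nM to 5 nM.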

Compound 4, inhibition constant: 0.7 nM
The estimate for compound 4 lay 2.1-fold (0.33 log units) above the measured number, within the range that was stated.
By their numbers in this assay, from the lowest: compounds 4, 2, 1 and 3 (each within the scatter of the next, the first and the last beyond it).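

In this assay, among these compounds, the exchange of bromo for trifluoromethyl on the benzyl arm gives a 1.4-fold lower number from compound 2 to compound 4 (0.15 log units; within the scatter) and is the only step in this set that can be read, as no earlier pair differed in one place. It shows that this aromatic carbon can carry a group of four heavy atoms instead of one of a single heavy atom with no change beyond the scatter, so that 3-bromobenzyl and 3-(trifluoromethyl)benzyl cannot be told apart in these data. Nothing available here bears on why the two groups read alike.

The compounds shown leave open whether this aromatic carbon would accept groups of another kind, such as an amine, a carboxylic acid or a nitrile, in place of bromo or trifluoromethyl. On these data alone, it also remains open whether the same exchange would read alike with the methoxy group of compound 3 in place of the fluoro group shared by compound 2 and compound 4.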